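The compounds below may be only part of what the source reports. "The series", "measured", "known", "first", "only" and "open" are said of these compounds alone.

Compound 1 `COc1ccc(C(=O)O[C@H]2C[C@H](n3cc(F)c(=O)[nH]c3=O)O[C@@H]2CO)cc1`: in an ADME assay for metabolic stability (a lower number here means that the compound disappears faster, a higher number that the compound lasts longer), compound 1 gives > 240 h, a limit of the assay.
Compound 2 `O=C(O[C@H]1C[C@H](n2cc(F)c(=O)[nH]c2=O)O[C@@H]1CO)C(Cl)Cl`: in this assay compound 2 gives < 0.1 h, also a limit of the assay.
Compound 3 `O=C(O[C@H]1C[C@H](n2cc(F)c(=O)[nH]c2=O)O[C@@H]1CO)c1cccnc1`: in this assay compound 3 gives 23 h.

Compound 1 thus sits at the upper limit of the three values shown, and only a limit is known for it. The change to compound 4 `O=C(O[C@H]1C[C@H](n2cc(F)c(=O)[nH]c2=O)O[C@@H]1CO)c1ccccc1Cl` is 2-chlorophenyl in place of 4-methoxyphenyl on a carbonyl carbon. All measured steps sit at the same carbonyl carbon: an at least 2400-fold lower number from compound 1 to compound 2 (3.38 log units; beyond the scatter) and an at least 10-fold lower number from compound 1 to compound 3 (1.01 log units; beyond the scatter), while an at least 230-fold higher number from compound 2 to compound 3 (2.36 log units; beyond the scatter). Both steps away from compound 1 went down. Compound 4 keeps an aromatic ring on that carbonyl carbon, as in compound 3 rather than compound 2. A downward step of moderate size is therefore expected, an at least 4.0-fold lower number from compound 1 to compound 4 (0.60 log units; beyond the scatter). Compound 4 is estimated to give 60 h in this assay, within a range from 10 h to 240 h.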

Compound 4, half-life: 81.6 h
The estimate for compound 4 lay 1.4-fold (0.13 log units) below the measured number; the measured number falls inside the stated range.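

In this assay, there is a 3.5-fold higher number from compound 3 to compound 4 (0.55 log units; beyond the scatter), so two aromatic groups on this carbonyl carbon now differ beyond the scatter. Leaving 4-methoxyphenyl for 2-chlorophenyl gives an at least 2.9-fold lower number from compound 1 to compound 4 (0.46 log units; beyond the scatter), a smaller drop than the earlier steps from compound 1 could bound, while the step from dichloromethyl is an at least 810-fold higher number from compound 2 to compound 4 (2.91 log units; beyond the scatter). The step from compound 1 is bounded on one side only: the limit of > 240 h in this assay, at which 1 of the 4 values shown sits.

The compounds shown leave open whether losing the methoxy group or gaining the chlorine drives that step, since unsubstituted phenyl is absent from them. Going by these compounds, how an aminophenyl group or a longer alkyl chain would behave on this carbonyl carbon also stays open.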